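The compounds below may be only part of what the source reports. "The series", "measured", "known", "first", "only" and "open" are said of these compounds alone.

Compound 1 `CCSC(=S)SCC(=O)c1ccc(C)cc1`: 3980 nM
Compound 2 `Cc1ccc(C(=O)CSC(=S)SC(C)C)cc1`: 25100 nM

In a functional assay on HeLa cells (Homo sapiens) for antiproliferative activity, read by resazurin assay (a higher number here means a weaker inhibitor, a lower number a stronger inhibitor), compound 1 holds the lower of the two numbers at 3980 nM, which makes it the stronger inhibitor of this pair. Compound 3 `CCSC(=S)SCC(=O)c1ccc(N(CC)CC)cc1` keeps the core of compound 1 but carries diethylamino in place of methyl on an aromatic carbon. Among the compounds with values here, the only measured step is a 6.3-fold higher number from compound 1 to compound 2 (0.80 log units; beyond the scatter). That modest step comes from a methyl on a saturated chain carbon, so it shows that this end of the molecule responds to change but says nothing direct about the aromatic carbon. Within the data shown here, no measured compound varies that site, so neither direction is favoured and a wide range is warranted. The expected change is a 1.3-fold higher number from compound 1 to compound 3 (0.10 log units; within the scatter), no clear shift. For compound 3 the estimate is 5000 nM, with an expected range of 1200 nM to 20000 nM.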

Compound 3, half-maximal inhibitory concentration: 3160 nM
Beside the measured number, compound 3's estimate is 1.6-fold (0.20 log units) above it; low and high end bracket the measured number.
By their numbers in this assay, from the lowest: compounds 3 and 1 (each within the scatter of the next); then compound 2.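

In this assay, the first change tried at this aromatic carbon, diethylamino in place of methyl, gives a 1.3-fold lower number from compound 1 to compound 3 (0.10 log units; within the scatter), so the two compounds cannot be told apart. This site therefore accepts a group of 5 heavy atoms, one of them nitrogen, where a methyl of 1 heavy atom stood, without a shift beyond the scatter, whereas the added methyl on the saturated chain carbon gave a 6.3-fold higher number from compound 1 to compound 2 (0.80 log units; beyond the scatter), a step beyond it. Nothing available explains why the number holds at this position.

As far as these compounds go, whether the same holds for a halogen such as chlorine, or for a carboxylic acid, on this aromatic carbon remains open. Also open, from the compounds shown here alone, is whether diethylamino would behave the same way on the core of compound 2, which carries the extra methyl on the chain.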